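A phenoxy group replaces heptyl on the shared core

A few compounds are considered here, and "the series" means these few. Any claim that something is new, unique, unknown or untested is made for them only; others in the source may bear on it.

In a functional assay on brain (Rattus norvegicus, strain Wistar) for inhibition (a higher number here means a weaker inhibitor, a lower number a stronger inhibitor), compound 1 `CCCCOc1ccc(-c2c(C)[nH]c(=O)n2C2CCCCC2)cc1` gives 13900 nM, compound 2 `Cc1[nH]c(=O)n(C2CCCCC2)c1-c1ccc(CC(C)C)cc1` gives 10900 nM and compound 3 `CCCCCCCc1ccc(-c2c(C)[nH]c(=O)n2C2CCCCC2)cc1` gives 8700 nM. These three values lie within the scatter of one another, so compound 3 cannot be separated from the other two. Compound 4 `Cc1[nH]c(=O)n(C2CCCCC2)c1-c1ccc(Oc2ccccc2)cc1` differs from compound 3 by one group: phenoxy in place of heptyl on an aromatic carbon.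

For the measured compounds named here, three measured steps bear on this change. Isobutyl in place of butoxy gave a 1.3-fold lower number from compound 1 to compound 2 (0.11 log units; within the scatter), heptyl in place of butoxy gave a 1.6-fold lower number from compound 1 to compound 3 (0.20 log units; within the scatter), and hexyl in place of isopropyl on the chain gave a 1.3-fold lower number from compound 2 to compound 3 (0.10 log units; within the scatter). All three stayed within the scatter. None of these groups holds a ring, as phenoxy does, so the data offer no direct guide to that feature, and the range must stay wide. In this assay, no change beyond the scatter is expected, and the estimated step is a 1.1-fold higher number from compound 3 to compound 4 (0.06 log units; within the scatter). The estimate for compound 4 is 10000 nM, with an expected range from 4000 nM to 25000 nM.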

Compound 4, half-maximal inhibitory concentration: 7900 nM
Estimate against measurement, compound 4: 1.3-fold (0.10 log units) above; low and high end bracket the measured number.
By their numbers in this assay, from the lowest: compounds 4, 3, 2 and 1 (each within the scatter of the next).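

Phenoxy is the first group in this set to bring a ring to this position, para to a large group, and in this assay that ring leaves the number inside the scatter: phenoxy in place of heptyl gives a 1.1-fold lower number from compound 3 to compound 4 (0.04 log units; within the scatter) and phenoxy in place of isobutyl gives a 1.4-fold lower number from compound 2 to compound 4 (0.14 log units; within the scatter) here. Phenyl in place of butyl on the same oxygen, a swap that keeps the oxygen and alters only what it carries, likewise gives a 1.8-fold lower number from compound 1 to compound 4 (0.25 log units; within the scatter) in this series. A flexible chain and an aromatic ring therefore cannot be told apart at this position, and no measurement at hand explains why.

From the compounds shown here alone, all four compounds carry a chain or phenoxy here, so it stays open whether an amine or a carboxylic acid would move the number beyond the scatter. Going by these compounds, a much smaller group, such as methyl, or a fluorine on the phenoxy ring, remains equally open.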